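The source may report more compounds than this note shows. Statements on the series, on what has been measured and on what is new or still open speak of the compounds shown alone.

In a functional assay on HepG2 cells (Homo sapiens) for cytotoxicity, read by MTT assay, with a stated time of 72 h (a higher number here means a weaker inhibitor, a lower number a stronger inhibitor), compound 1 `O=C1C=CCC/C1=C\C=C\c1ccccc1` gives 7100 nM and lies within the scatter of both other measured compounds. Compound 2 `Cc1ccc(/C=C/C=C2\CCC=CC2=O)cc1` gives 8600 nM and compound 3 `O=C1C=CCC/C1=C\C=C\c1ccc(Cl)cc1` gives 3700 nM in the same read-out. Compound 4 `O=C1C=CCC/C1=C\C=C\c1ccccc1[N+](=O)[O-]` differs from compound 1 through nitro in place of hydrogen on an aromatic carbon on the shared core: nitro in place of hydrogen on an aromatic carbon, ortho to a large group. Among the measured compounds shown here, two measured steps bear on this change, and neither leaves the scatter (a 1.2-fold higher number from compound 1 to compound 2 (0.08 log units; within the scatter) and a 1.9-fold lower number from compound 1 to compound 3 (0.28 log units; within the scatter)). For the measured compounds named here, only the step between the two substituted compounds goes beyond it, and modestly (a 2.3-fold lower number from compound 2 to compound 3 (0.37 log units; beyond the scatter)). Going by the values given here, no measured compound carries nitro, so this guide is indirect and the range stays wide. In this assay a step beyond the scatter is therefore not expected, and the estimated step is small (a 1.4-fold lower number from compound 1 to compound 4 (0.15 log units; within the scatter)). The estimated value for compound 4 is 5000 nM within an expected range of 1800 nM to 14000 nM in this read-out.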

Compound 4, half-maximal inhibitory concentration: 6800 nM
Compound 4: the middle estimate sits 1.4-fold (0.13 log units) below what was measured; the measured number falls inside the stated range.
By their numbers in this assay, from the lowest: compounds 3, 4, 1 and 2 (each within the scatter of the next, the first and the last beyond it).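

In this assay, nitro in place of hydrogen on an aromatic carbon, ortho to a large group, gives a 1.0-fold lower number from compound 1 to compound 4 (0.02 log units; within the scatter). This is the first result shown for this place on the aromatic ring, and it indicates that a group of three heavy atoms with two hydrogen-bond acceptors can stand there without a step beyond the scatter, so this one substitution offers no gain or loss to follow up in this read-out. Nothing measured here explains why the nitro compound stays within the scatter of compound 1.

As far as these compounds go, whether an amine or a carboxylic acid at this same place would also stay within the scatter remains open. From the compounds shown here alone, it is also open whether nitro on another carbon of the aromatic ring would give a comparable number.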